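The source may hold more compounds than are shown below. What is called first, only, known or untested is meant among the compounds shown, and "the series" means these compounds.

Of the compounds shown here, three have been measured in an assay on CHO cells for displacement of a labelled ligand from adenosine receptor A3 (Homo sapiens), tested at 10 uM; on this read-out lower numbers stand for less inhibition and higher numbers for more inhibition at the one concentration tested (going by the name of the read-out). Compound 1 `Nc1ncnc2c1ncn2[C@H]1C[C@H](CO)CO1` gives 7% in this assay. Compound 2 `OC[C@]1(O)CO[C@@H](n2cnc3c(NCc4cccc(I)c4)ncnc32)[C@@H]1O` gives 45%. Compound 3 `Nc1ncnc2c1ncn2[C@@H]1OC[C@@](O)(CO)[C@H]1O` gives 10%. For the measured compounds named here, the one measured step between two compounds that differ in a single place is a number 35 percentage points lower from compound 2 to compound 3 (beyond the scatter), which places a hydrogen where a 3-iodobenzyl stood on a nitrogen on an aromatic ring. On the numbers shown, compound 3 stands second of the three: its value and that of compound 1 lie within the scatter of each other, so no order between those two can be claimed, while compound 2 sits well above both.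

Compound 4 `CCNC(=O)OC[C@]1(O)CO[C@@H](n2cnc3c(N)ncnc32)[C@@H]1O` has not yet been measured. It differs from compound 3 by ethylcarbamoyl in place of hydrogen on an oxygen on a saturated carbon, read one bond further out as hydroxy to (ethylcarbamoyl)oxy. Going by the values given here, the only measured step, from compound 2 to compound 3, changes a different part of the molecule, so no measured pair speaks directly to this change. With nothing pointing in either direction, a step within the scatter is the plainest expectation. Compound 4 is therefore estimated to give 10%, with a range from 0% to 25%. The step of no change at the digits printed from compound 3 to compound 4 (within the scatter) that this estimate means is expected to stay within the scatter.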

Compound 4, a percentage reported as inhibition, at one concentration (the size of the read-out at that concentration, not a potency): 6%
Estimate against measurement, compound 4: 4 percentage points above, within the range that was stated.
By their numbers in this assay, from the lowest: compounds 4, 1 and 3 (each within the scatter of the next); then compound 2.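

In this assay, putting ethylcarbamoyl in place of hydrogen on the oxygen of the hydroxymethyl group gives a number 4 percentage points lower from compound 3 to compound 4 (within the scatter). For the compounds shown here, this is the first measured change at this position, and it differs in size from the only other measured step, a number 35 percentage points lower from compound 2 to compound 3 (beyond the scatter), which concerns the 3-iodobenzyl group on a nitrogen on an aromatic ring. The hydroxy can therefore become (ethylcarbamoyl)oxy, an addition of 5 heavy atoms, with no difference that can be claimed, although compound 3 at 10% is already so low that a further fall would be hard to see, and nothing available explains this outcome.

From the compounds shown here alone, it remains open whether ethylcarbamoyl on this oxygen would matter in a compound that also carries 3-iodobenzyl on the nitrogen, as compound 2 does at 45%. Also open, going by these compounds, is how other groups on the same oxygen would read in this assay, such as a methyl ether, an acetyl ester or a longer chain such as butylcarbamoyl.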